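The source may hold more compounds than are shown below. What is called first, only, known or untested is meant among the compounds shown, and "the series" means these compounds.

Measured compounds and their values:

- compound 1, `Cc1ccc(-c2nc3sc(Cc4ccc(Cl)cc4)nn3c2Br)cc1`: > 250000 nM
- compound 2, `Clc1ccc(Cc2nn3c(Br)c(-c4ccc(Cl)cc4Cl)nc3s2)cc1`: 31000 nM
- compound 3, `O=[N+]([O-])c1ccc(-c2nc3sc(Cc4ccc(Cl)cc4)nn3c2Br)cc1`: 94000 nM

The three compounds share one core and differ only in the group on the aryl ring attached to it. In a functional assay on L1210 cells (Mus musculus) for cytotoxicity, with a stated time of 48 h (on this read-out higher numbers stand for weaker inhibition and lower numbers for stronger inhibition), compound 1 gives > 250000 nM, and this is not a number but a limit of the assay (the limit of > 250000 nM in this assay, at which 1 of the 3 values shown sits). Compound 2 carries a 2,4-dichlorophenyl in place of the 4-methylphenyl and gives 31000 nM, which is an at least 8.0-fold lower number from compound 1 to compound 2 (0.90 log units; beyond the scatter). Compound 3 carries a nitro in place of the methyl and gives 94000 nM, which is an at least 2.6-fold lower number from compound 1 to compound 3 (0.42 log units; beyond the scatter). Compound 1 thus stands at the weak end of the set, with only a limit known.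

Compound 4, `Cc1ccc(-c2nc3sc(Cc4ccc(Cl)cc4)nn3c2C=O)cc1`, keeps the 4-methylphenyl of compound 1 and changes a different place: formyl in place of bromo on an aromatic carbon. Neither of the two measured steps touches this position; both alter the aryl group instead, so they give no direct guide to the size or direction of this change. The estimate for compound 4 therefore rests mostly on the limit of compound 1, with wide room in both directions. Compound 4 is expected to give about 150000 nM, within a range from 30000 nM to 500000 nM, which would mean an at least 1.6-fold lower number from compound 1 to compound 4 (0.22 log units; that floor lies within the scatter).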

Compound 4, half-maximal inhibitory concentration: 23000 nM
Estimate against measurement, compound 4: 6.5-fold (0.81 log units) above; measured number below the stated range.
By their numbers in this assay, from the lowest: compounds 4 and 2 (each within the scatter of the next); then compound 3. At a limit, above all of these: compound 1.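

Within the data shown here, the earlier steps all altered the aryl group, so compound 4 gives the first reading at this other place, an aromatic carbon of a five-membered aromatic ring, next to the ring nitrogen. In this assay, formyl in place of bromo gives an at least 10-fold lower number from compound 1 to compound 4 (1.03 log units; beyond the scatter), which shows that with the 4-methylphenyl kept, a small change at this carbon alone is enough for a large step, so the aryl group is not the only part of these compounds that moves the number. How large the step really is cannot be told, because compound 1 has no exact value, only a limit: the limit of > 250000 nM in this assay, at which 1 of the 4 values shown sits.

The compounds shown leave open whether the lower number comes from the formyl itself or simply from the loss of bromo, and a hydrogen, an amine, a hydroxymethyl or a carboxylic acid at this carbon would help separate the two. They also leave open whether formyl in place of bromo gives a similar step on the 2,4-dichlorophenyl of compound 2 or on the nitro-bearing aryl ring of compound 3.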